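From 1H-tetrazol-5-yl to carboxy on the shared core

The compounds below may be only part of what the source reports. "The series", "measured", "known", "first", "only" and "open" are said of these compounds alone.

Compound 2 `COc1cc(OC(F)(F)F)cc(-c2ccc3c(c2)CC[C@H](CCc2nnn[nH]2)O3)c1F` carries a 2-(1H-tetrazol-5-yl)ethyl chain on the shared core. In a functional assay on HEK293 cells for agonist activity at Free fatty acid receptor 1 (Homo sapiens), read by HTRF and inositol phosphate accumulation, with a stated time of 60 min (on this read-out lower numbers stand for an effect already at smaller amounts and higher numbers for an effect only at larger amounts of compound), compound 2 gives only a limit, > 10000 nM. Compound 3 `Fc1ccc(OC(F)(F)F)cc1-c1ccc2c(c1)CC[C@H](CCc1nnn[nH]1)O2` differs from compound 2 by hydrogen in place of methoxy on an aromatic carbon. In this assay compound 3 also returns only a limit, > 10000 nM. The step that the two limits leave unreadable from compound 2 to compound 3 therefore cannot be read. Compound 1 `COc1cc(Oc2ncc(C)s2)cc(-c2ccc3c(c2)CC[C@H](CCC(=O)O)O3)c1F`, which carries a carboxy group with a different aryl ether, likewise gives only a limit in this assay, > 10000 nM. Among the compounds with values here, every value shown sits at the same limit, (the limit of > 10000 nM in this assay, at which 3 of the 3 values shown sit), so no measured step bears on the change from compound 2 to compound 4 `COc1cc(OC(F)(F)F)cc(-c2ccc3c(c2)CC[C@H](CCC(=O)O)O3)c1F`, which is carboxy in place of 1H-tetrazol-5-yl on a saturated chain carbon, two bonds along the chain from a saturated ring carbon. Compound 1 already shows that a carboxy group on this chain does not bring the read-out within range. On that showing compound 4 is expected to sit at 10000 nM in this assay, with an estimated range from 3000 nM to 30000 nM. The step of a number no higher from compound 2 to compound 4 (the limit leaves the size open) is thus expected to be none beyond the scatter.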

Compound 4, half-maximal effective concentration: 4400 nM
Beside the measured number, compound 4's estimate is 2.3-fold (0.36 log units) above it; the range from low to high includes it.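

Compound 4 is the first compound here to give a number rather than a limit, and the other compounds remain at that limit: the limit of > 10000 nM in this assay, at which 3 of the 4 values shown sit.

In this assay, the change on the saturated chain carbon, two bonds along the chain from a saturated ring carbon, gives an at least 2.2-fold lower number from compound 2 to compound 4 (0.35 log units; beyond the scatter). The change on the oxygen gives an at least 2.2-fold lower number from compound 1 to compound 4 (0.35 log units; beyond the scatter), so neither carboxy alone, as in compound 1, nor trifluoromethyl alone, as in compound 2, gives a number among these compounds; only compound 4, with both, does.

Going by these compounds, the full size of both steps stays open, and the step from compound 2 to compound 3 cannot be read. Also open, on these data alone, is how the read-out would respond to hydrogen in place of methoxy alongside carboxy, to a longer chain bearing the carboxylic acid, or to a primary amide in its place.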